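Replacing bromo with methyl in compound 3: working notes

This account rests on a few compounds, and the source may have more. Where it says the series, first, only, none or still open, it means among the compounds named here.

Values so far in a functional assay on HepG2 cells (Homo sapiens) for inhibition, read by MTT assay, with a stated time of 72 h (on this read-out higher numbers stand for weaker inhibition and lower numbers for stronger inhibition), are:
- compound 1 `Cc1cc2occ(-c3nc(-c4ccccc4)c(-c4ccccc4)n3-c3ccc([N+](=O)[O-])cc3)c(=O)c2cc1Cl` gives 25000 nM
- compound 2 `Cc1cc2occ(-c3nc(-c4ccccc4)c(-c4ccccc4)n3-c3cccc([N+](=O)[O-])c3)c(=O)c2cc1Cl` gives 25000 nM
- compound 3 `Cc1cc2occ(-c3nc(-c4ccccc4)c(-c4ccccc4)n3-c3ccc(Br)cc3)c(=O)c2cc1Cl` gives 6250 nM

Compound 3 holds the lowest number of the three, and its steps to both others lie beyond the scatter. The next case is compound 4 `Cc1ccc(-n2c(-c3coc4cc(C)c(Cl)cc4c3=O)nc(-c3ccccc3)c2-c2ccccc2)cc1`, with methyl in place of bromo on an aromatic carbon, para to a large group, which counts as methyl in place of bromo on an aromatic carbon. Cut one bond further out, this reads 4-bromophenyl to 4-methylphenyl.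

Within the data shown here, three measured steps bear on this substituent. Moving the nitro group gave no change at the digits printed from compound 1 to compound 2 (within the scatter). Bromo in place of nitro gave a 4.0-fold lower number from compound 1 to compound 3 (0.60 log units; beyond the scatter), and the matching comparison gave a 4.0-fold lower number from compound 2 to compound 3 (0.60 log units; beyond the scatter). Both are modest, and neither has methyl on either side, so they guide the size of the new step only loosely. Among the measured compounds shown here, no methyl compound has been measured.

For the measured compounds named here, compound 3 at 6250 nM is the only bromo compound and also the lowest number, so a small upward move in this assay is expected, less than the measured bromo steps and possibly within the scatter. The expected change is a 1.6-fold higher number from compound 3 to compound 4 (0.20 log units; within the scatter). For compound 4 the estimate is 10000 nM, with an expected range of 4000 nM to 25000 nM.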

Compound 4, half-maximal inhibitory concentration: 6250 nM
Compound 4: the middle estimate sits 1.6-fold (0.20 log units) above what was measured; low and high end bracket the measured number.
By their numbers in this assay, from the lowest: compounds 3 and 4 (each within the scatter of the next); then compounds 1 and 2 (each within the scatter of the next).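

In this assay, among these compounds, methyl in place of bromo gives no change at the digits printed from compound 3 to compound 4 (within the scatter), so the two groups cannot be told apart at this place on the ring, a comparison the earlier compounds could not offer as none carried methyl. The gap to the nitro compounds also proves not to be specific to bromo: methyl in place of nitro gives a 4.0-fold lower number from compound 1 to compound 4 (0.60 log units; beyond the scatter), and 4-methylphenyl in place of 3-nitrophenyl gives a 4.0-fold lower number from compound 2 to compound 4 (0.60 log units; beyond the scatter), the same size as the bromo steps a 4.0-fold lower number from compound 1 to compound 3 (0.60 log units; beyond the scatter) and a 4.0-fold lower number from compound 2 to compound 3 (0.60 log units; beyond the scatter). No measurement is available that accounts for bromo and methyl matching here or for the separation of both from the nitro compounds.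

From the compounds shown here alone, it remains open whether an amine, a carboxylic acid or a methoxy group at this place would stay with bromo and methyl or fall with the nitro compounds, and whether the unsubstituted phenyl would match either set. Going by these compounds, it is also open whether the match between bromo and methyl would hold with a longer chain on this ring or with another group in place of the chloro on the shared core.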